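This account rests on a few compounds, and the source may have more. Where it says the series, first, only, none or still open, it means among the compounds named here.

Measured in a functional assay on HUVEC cells (Homo sapiens) for antiproliferative activity, read by WST assay, with a stated time of 5 days; on this read-out lower numbers stand for stronger inhibition and higher numbers for weaker inhibition:
compound 1 `Cc1cc(NC(=O)c2cc(C)nn2C)cc(Oc2ccc3nc(NC(=O)C4CC4)nn3c2)c1`: 47 nM
compound 2 `Cc1cc(C(=O)Nc2cccc(Oc3ccc4nc(NC(=O)C5CC5)cn4c3)c2)n(C)n1`: 1.1 nM

Compound 2, at 1.1 nM, holds the lower of the two numbers, and compound 1 stands higher by a gap beyond the scatter. Compound 3 `Cc1cc(C(=O)Nc2cc(Oc3ccc4nc(NC(=O)C5CC5)cn4c3)ccc2C)n(C)n1` carries methyl in place of hydrogen on an aromatic carbon, ortho to a ((1,3-dimethyl-1H-pyrazol-5-yl)carbonyl)amino group (methyl in place of hydrogen on an aromatic carbon). Within the data shown here, no measured pair shows this change alone, so its size remains a judgement. A small move toward stronger inhibition is expected, perhaps within the scatter, an estimated 1.6-fold lower number from compound 2 to compound 3 (0.20 log units; within the scatter). The estimated value for compound 3 is 0.7 nM, expected between 0.2 nM and 3 nM.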

Compound 3, half-maximal inhibitory concentration in the HUVEC assay: 0.8 nM
The estimate for compound 3 lay 1.1-fold (0.06 log units) below the measured number; measured number inside the range.
By their numbers in the HUVEC assay, from the lowest: compounds 3 and 2 (each within the scatter of the next); then compound 1.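

In the HUVEC assay this position accepts a methyl without any change beyond the scatter (a 1.4-fold lower number from compound 2 to compound 3 (0.14 log units; within the scatter)), so the added carbon, ortho to the ((1,3-dimethyl-1H-pyrazol-5-yl)carbonyl)amino group, costs no inhibition. The same change does separate the two compounds in a physicochemical assay for solubility, measured as kinetic solubility, at pH 6.8 (a lower number here means a less soluble compound, a higher number a more soluble compound), with a step beyond the scatter: the measured solubility of compound 2, 0.73 ug/mL, and of compound 3, 2.9 ug/mL, a 4.0-fold higher number (0.60 log units; beyond the scatter). In the physicochemical assay compound 2 gives 0.73 ug/mL and compound 3 gives 2.9 ug/mL. The compounds shown leave open whether a fluorine, an ethyl or a methoxy at this position would give the same result on both read-outs.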